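Chloro added on the thiourea aryl ring: compound 4

The compounds below may be only part of what the source reports. "The series", "measured", "known", "first", "only" and "open" are said of these compounds alone.

Compound 1 `CNC(=O)c1cc(Oc2cccc(NC(=S)Nc3ccc(Cl)cc3Cl)c2)ccn1` and compound 2 `CNC(=O)c1cc(Oc2cccc(NC(=S)Nc3ccc(Cl)cc3)c2)ccn1` share one core; in a functional assay on HCT-116 cells (Homo sapiens) for cytotoxicity, read by MTT assay, with a stated time of 48 h (a lower number here means a stronger inhibitor, a higher number a weaker inhibitor), compound 1 gives 41200 nM and compound 2 gives 39400 nM. The change chloro in place of hydrogen on an aromatic carbon made a 1.0-fold higher number from compound 2 to compound 1 (0.02 log units; within the scatter). Compound 3 `O=C(c1cc(Oc2cccc(NC(=S)Nc3cccc(C(F)(F)F)c3)c2)ccn1)N1CCCC1` has a different core; how the two cores differ is not broken down here. In this assay compound 3 gives 19200 nM, the lowest of the three numbers and beyond the scatter from compound 2 and compound 1. Compound 4 `O=C(c1cc(Oc2cccc(NC(=S)Nc3ccc(Cl)c(C(F)(F)F)c3)c2)ccn1)N1CCCC1` carries the change (chloro in place of hydrogen on an aromatic carbon). This is the same kind of change as from compound 2 to compound 1, not the same: there the place was ortho to a large group and meta to a chloro group, here it is ortho to a trifluoromethyl group and para to a large group. The expected step of a 1.1-fold lower number from compound 3 to compound 4 (0.05 log units; within the scatter) rests on the earlier one, a 1.0-fold higher number from compound 2 to compound 1 (0.02 log units; within the scatter), which stayed within the scatter. Compound 4 is therefore estimated at 17000 nM in this assay, expected between 7000 nM and 40000 nM.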

Compound 4, half-maximal inhibitory concentration: 22400 nM
The estimate for compound 4 lay 1.3-fold (0.12 log units) below the measured number; low and high end bracket the measured number.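

In this assay, chloro in place of hydrogen on an aromatic carbon gives a 1.2-fold higher number from compound 3 to compound 4 (0.07 log units; within the scatter), and this agrees with the earlier step on the other core: the same change on two cores in this assay, a 1.0-fold higher number (0.02 log units; within the scatter) from compound 2 to compound 1 and a 1.2-fold higher number (0.07 log units; within the scatter) from compound 3 to compound 4, 1.1-fold (0.05 log units) apart, within the scatter of two such steps. On these two cores, then, the change carries over as a step within the scatter, and the earlier reading served as a fair guide to the core of compound 3. Two pairs, with the chloro at a different place in each, do not show that the change would stay this small on a further core or at a further place on the ring.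

Open, as far as these compounds go, is whether an amine, a carboxylic acid or a methoxy group on the thiourea aryl ring would move the number beyond the scatter. Also open, from the compounds shown here alone, is what a urea in place of the thiourea would do on either core.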